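Swapping the aniline for a carboxymethyl pyrazole on the shared core

The source may report more compounds than this note shows. Statements on the series, on what has been measured and on what is new or still open speak of the compounds shown alone.

Measured compounds:
compound 1, `COc1ncc(-c2ccc3ncnc(Nc4ccc(OCCO)cc4)c3c2)cc1NS(=O)(=O)c1ccc(F)cc1F`, in a functional assay on HCT-116 cells (Homo sapiens) for antiproliferative activity, read by sulforhodamine B assay, with a stated time of 72 h (on this read-out lower numbers stand for stronger inhibition and higher numbers for weaker inhibition), compound 1 gives 1060 nM
compound 2, `COc1ncc(-c2ccc3ncnc(Nc4cnn(CCC(=O)O)c4)c3c2)cc1NS(C)(=O)=O`, in this assay compound 2 gives 1290 nM

The two numbers lie within the usual scatter of each other, so compound 1 cannot be set apart from compound 2 on this assay; it is simply the one with the lower figure of the pair. Compound 3, `COc1ncc(-c2ccc3ncnc(Nc4cnn(CC(=O)O)c4)c3c2)cc1NS(=O)(=O)c1ccc(F)cc1F`, keeps the difluorophenyl sulfonamide of compound 1 and changes the amine substituent: 1-(carboxymethyl)-1H-pyrazol-4-yl in place of 4-(2-hydroxyethoxy)phenyl on a nitrogen on an aromatic ring. Compound 2 already carries a pyrazole bearing a short acid chain on the same nitrogen, with a methylsulfonamide instead, and its value sits close to that of compound 1. Going by the values given here, no measured pair isolates this single exchange, so the step is expected to be small, with no clear direction beyond the scatter, in line with how compound 2 sits beside compound 1. Compound 3 is therefore estimated at 1100 nM, with a likely range from 400 nM to 3000 nM, corresponding to an expected step of a 1.0-fold higher number from compound 1 to compound 3 (0.02 log units; within the scatter).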

Compound 3, half-maximal inhibitory concentration: 1540 nM
Estimate against measurement, compound 3: 1.4-fold (0.15 log units) below; low and high end bracket the measured number.
By their numbers in this assay, from the lowest: compounds 1, 2 and 3 (each within the scatter of the next).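

Going by these compounds alone, with the 2,4-difluorophenyl sulfonamide held constant, compound 3 gives the first direct reading of an exchange at this position on the shared core. In this assay, the step is a 1.5-fold higher number from compound 1 to compound 3 (0.16 log units; within the scatter), so 1-(carboxymethyl)-1H-pyrazol-4-yl and 4-(2-hydroxyethoxy)phenyl on this nitrogen cannot be told apart. The exchange replaces a six-membered aromatic ring of carbon only with a five-membered aromatic ring with 2 hetero atoms, and the read-out does not separate the two. No measured property bears on this result, and nothing here accounts for it.

Going by these compounds, it remains open whether a longer carboxylic acid chain on the pyrazole would matter with the difluorophenyl sulfonamide in place, since compound 2 and compound 3 differ in two places. A primary amine or an amide at the end of that chain is equally unresolved.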